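Trading an aromatic ring for a short chain

The source may report more compounds than this note shows. Statements on the series, on what has been measured and on what is new or still open speak of the compounds shown alone.

Compound 2 `Nc1nc(O)c2c(n1)n(C1OC(CO)[C@@H](O)[C@H]1O)c(=O)n2Cc1ccc(Cl)cc1` stands second highest of the three numbers in a functional assay (B cells) with Mus musculus as the target (on this read-out higher numbers stand for an effect only at larger amounts of compound and lower numbers for an effect already at smaller amounts), where compound 2 gives 14 uM. Compound 3 `Nc1nc(O)c2c(n1)n(C1OC(CO)[C@@H](O)[C@H]1O)c(=O)n2Cc1ccc(OCc2ccccc2)cc1` gives 8 uM, and the step of a 1.8-fold lower number from compound 2 to compound 3 (0.24 log units; within the scatter) shows that altering a substituent on that aromatic ring leaves the number within the scatter. Among the measured compounds shown here, compound 1 `C=CCn1c(=O)n(C2CCC(CO)C2)c2nc(N)nc(O)c21`, which carries a short chain on the same nitrogen and a different ring elsewhere, gives 226 uM; no single-point step links it to compound 2, yet its number is far higher. Compound 4 `CCCCn1c(=O)n(C2OC(CO)[C@@H](O)[C@H]2O)c2nc(N)nc(O)c21` differs from compound 2 by propyl in place of 4-chlorophenyl on a saturated chain carbon bound to an aromatic nitrogen. For the measured compounds named here, no measured step isolates this change, so the expectation is uncertain. Because compound 1 gives 226 uM with a chain in that position, weaker activity is expected after the step of a 6.4-fold higher number from compound 2 to compound 4 (0.81 log units; beyond the scatter). Compound 4 is therefore estimated at 90 uM, with a range from 30 uM to 300 uM.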

Compound 4, concentration for half-maximal effect: 11 uM
The estimate for compound 4 lay 8.2-fold (0.91 log units) above the measured number; measured number outside the range, below it.
By their numbers in this assay, from the lowest: compounds 3, 4 and 2 (each within the scatter of the next); then compound 1.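

In this assay, the step of a 1.3-fold lower number from compound 2 to compound 4 (0.10 log units; within the scatter) shows that 4-chlorophenyl can give way to propyl, on a saturated chain carbon bound to an aromatic nitrogen, with the number staying within the scatter. Among compounds 2, 3 and 4, then, an aromatic ring at this position is not needed to keep the number in this range. Nothing measured here explains why the two groups read alike. On these data alone, whether a longer chain such as octyl, or a chain carrying an amine or a carboxylic acid, would read the same remains open.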